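A few compounds are considered here, and "the series" means these few. Any claim that something is new, unique, unknown or untested is made for them only; others in the source may bear on it.

Compound 1 `COc1ccc(S(=O)(=O)N2CCc3cccc(-c4ccc(N)cc4)c32)cc1` gives 249 nM in a functional assay on KB cells (Homo sapiens) for inhibition, with a stated time of 72 h (on this read-out higher numbers stand for weaker inhibition and lower numbers for stronger inhibition), the highest of the three numbers in hand. Compound 2 `COc1ccc(S(=O)(=O)N2CCc3cccc(-c4ccc(F)nc4)c32)cc1` gives 143 nM and compound 3 `COc1ccc(S(=O)(=O)N2CCc3cccc(-c4ccncc4)c32)cc1` gives 96 nM in this assay. Compound 4 `COc1ccc(S(=O)(=O)N2CCc3cccc(-c4ccccc4)c32)cc1` differs from compound 1 by hydrogen in place of amino on an aromatic carbon. Going by the values given here, the steps that bear on this are the two that also remove the 4-aminophenyl group: a 1.7-fold lower number from compound 1 to compound 2 (0.24 log units; within the scatter) and a 2.6-fold lower number from compound 1 to compound 3 (0.41 log units; beyond the scatter). Both lower the number, yet only one of them lies beyond the scatter, and neither tests a plain phenyl. A small step is therefore expected in this assay, most likely within the scatter and, if anything, toward a lower number: a 1.4-fold lower number from compound 1 to compound 4 (0.14 log units; within the scatter). Compound 4 is estimated at 180 nM in this assay, with a range of 80 nM to 400 nM.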

Compound 4, half-maximal inhibitory concentration: 120 nM
Estimate against measurement, compound 4: 1.5-fold (0.18 log units) above; the measured number falls inside the stated range.
By their numbers in this assay, from the lowest: compounds 3, 4, 2 and 1 (each within the scatter of the next, the first and the last beyond it).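

The plain phenyl isolates the amino group on the ring of compound 1: a 2.1-fold lower number from compound 1 to compound 4 (0.32 log units; beyond the scatter) in this assay with no ring nitrogen involved. Phenyl, pyridin-4-yl and 6-fluoropyridin-3-yl are not told apart at this position, with a 1.3-fold higher number from compound 3 to compound 4 (0.10 log units; within the scatter) and a 1.2-fold lower number from compound 2 to compound 4 (0.08 log units; within the scatter) both staying within the scatter. No measurement here offers an explanation for the amino step.

Going by these compounds, whether the higher number is particular to amino at this place, para to a large group, remains open. A hydroxyl, a dimethylamino group or a carboxylic acid there would test this.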